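The source may hold more compounds than are shown below. What is called first, only, known or untested is meant among the compounds shown, and "the series" means these compounds.

Compound 1 `CC(C)(C)n1cc2c(n1)C(=O)CC1(CCN(C(=O)c3cc(-c4ccccc4)nc4ccccc34)CC1)O2` carries a phenyl on its shared core. In a functional assay on MDA-MB-231 cells (Homo sapiens) for inhibition, read by MTT assay, with a stated time of 72 h (on this read-out higher numbers stand for weaker inhibition and lower numbers for stronger inhibition), compound 1 gives only a limit of the assay, > 10000 nM, and not a number. Compound 2 `CN(C)c1ccc(-c2cc(C(=O)N3CCC4(CC3)CC(=O)c3nn(C(C)(C)C)cc3O4)c3ccccc3n2)cc1` adds a dimethylamino on an aromatic carbon of that phenyl. In this assay compound 2 likewise reaches only a limit, > 10000 nM. Compound 3 `CN1CCN(c2cc(C(=O)N3CCC4(CC3)CC(=O)c3nn(C(C)(C)C)cc3O4)c3ccccc3n2)CC1` puts 4-methylpiperazin-1-yl where compound 1 holds phenyl, and in this assay compound 3 gives 8130 nM. The steps among these three are hard to read: a step that the two limits leave unreadable from compound 1 to compound 2, while an at least 1.2-fold lower number from compound 1 to compound 3 (0.08 log units; that floor lies within the scatter) and an at least 1.2-fold lower number from compound 2 to compound 3 (0.08 log units; that floor lies within the scatter) are floors set by the limit of > 10000 nM in this assay, at which 2 of the 3 values shown sit. Compound 4 `Cc1cc(C(=O)N2CCC3(CC2)CC(=O)c2nn(C(C)(C)C)cc2O3)c2ccccc2n1` differs from compound 1 by methyl in place of phenyl on an aromatic carbon: phenyl leaves and methyl enters. Going by the values given here, no measured step swaps phenyl for methyl; the nearest is the move to 4-methylpiperazin-1-yl, an at least 1.2-fold lower number from compound 1 to compound 3 (0.08 log units; that floor lies within the scatter), whose floor lies within the scatter, so the weak result on compound 1 is the main guide, and no step beyond the scatter is expected. For compound 4 the expected step is a step that the limit leaves unreadable from compound 1 to compound 4. Compound 4 is therefore estimated at 12000 nM in this assay, within 4000 nM to 40000 nM.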

Compound 4, half-maximal inhibitory concentration: 4860 nM
Estimate against measurement, compound 4: 2.5-fold (0.39 log units) above, and the stated range covers the measured number.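

In this assay, the group on this aromatic carbon, next to the ring nitrogen, now gives steps that clear the scatter, as replacing either aryl group with methyl produces an at least 2.0-fold lower number from compound 1 to compound 4 (0.31 log units; beyond the scatter) and an at least 2.0-fold lower number from compound 2 to compound 4 (0.31 log units; beyond the scatter). Thus, on the shared core, neither phenyl nor 4-(dimethylamino)phenyl is needed at this position for a measurable effect in these cells, and a single methyl is enough to give a numerical value. The comparison with the other non-aryl group is different, since a 1.7-fold lower number from compound 3 to compound 4 (0.22 log units; within the scatter) leaves methyl and 4-methylpiperazin-1-yl indistinguishable, and the two steps from the aryl compounds are only floors, with their full size unknown, because compound 1 and compound 2 sit at an assay limit: the limit of > 10000 nM in this assay, at which 2 of the 4 values shown sit.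

The compounds shown leave open whether an ethyl group, a longer chain, a simple primary amine or a morpholine at this position would improve on compound 4, which gives 4860 nM. They also leave open whether a small group here would have the same effect if the rest of the shared core were changed.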